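Isopropoxy for isobutyl on a carbonyl carbon

This account rests on a few compounds, and the source may have more. Where it says the series, first, only, none or still open, it means among the compounds named here.

Of the compounds shown here, two have numbers so far, compound 1 (`CC(=O)N1CC(CC(=O)NO)(NS(=O)(=O)c2ccc(Cc3cc(C)nc4ccccc34)cc2)C1`) and compound 2 (`Cc1cc(COc2ccc(S(=O)(=O)NC3(CC(=O)NO)CN(C(=O)CC(C)C)C3)cc2)c2ccccc2n1`). In a physicochemical assay for solubility, with a stated time of 24 h, tested at 30 mg/mL (on this read-out lower numbers stand for lower solubility and higher numbers for higher solubility), compound 1 reads 1900000 nM and compound 2 reads 900000 nM on the same scale. Compound 2 thus holds the lower of the two numbers, and its gap to compound 1 lies beyond the usual scatter of repeated measurements. The next compound, compound 3 (`Cc1cc(COc2ccc(S(=O)(=O)NC3(CC(=O)NO)CN(C(=O)OC(C)C)C3)cc2)c2ccccc2n1`), differs from compound 2 in one place: isopropoxy stands in place of isobutyl on a carbonyl carbon (isopropoxy in place of isobutyl on a carbonyl carbon). The same difference, cut one bond further out, reads isobutylcarbonyl to isopropoxycarbonyl. For the measured compounds named here, no pair of measured compounds shows this change or any other single change, so the data offer no direct guide to its size. The expectation therefore stays anchored on compound 2 at 900000 nM in the absence of other evidence. In this assay the estimated step of a 1.2-fold lower number from compound 2 to compound 3 (0.08 log units; within the scatter) is small and slightly downward, within the usual scatter. The estimated value for compound 3 is 750000 nM (expected range 300000 nM to 1900000 nM).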

Compound 3, solubility: 1100000 nM
For compound 3 the middle estimate is 1.5-fold (0.17 log units) below the measured one; measured number inside the range.
By their numbers in this assay, from the lowest: compounds 2, 3 and 1 (each within the scatter of the next, the first and the last beyond it).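

For the compounds shown here, at this position, on a carbonyl carbon whose other neighbours are an amide-type nitrogen in a ring, putting isopropoxy in place of isobutyl gives the first single-place step in this assay: a 1.2-fold higher number from compound 2 to compound 3 (0.09 log units; within the scatter). Both groups carry 4 heavy atoms, and the entering isopropoxy brings 1 hydrogen-bond acceptor where isobutyl has 0, yet the read-out does not separate the two compounds on this pair. Nothing measured here speaks to why the two compounds stand so close.

The compounds shown leave open how this assay would respond to a different kind of group on the same carbonyl carbon, such as an amine, a carboxylic acid or a longer chain. Also open, going by these compounds, is whether isopropoxy in place of isobutyl would give a similar step on the core of compound 1, as a single pair, compound 2 with compound 3, is all that carries this change so far.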